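Shifting the Furan Attachment Point: From Compound 2 to Compound 3

A few compounds are considered here, and "the series" means these few. Any claim that something is new, unique, unknown or untested is made for them only; others in the source may bear on it.

Of the compounds shown here, two of this set have been measured in an assay on membranes from CHO cells for displacement of a labelled ligand from adenosine receptor A1 (Homo sapiens), read by scintillation counting, with a stated time of 60 min, tested at 1 uM; on this read-out higher numbers stand for more inhibition at the one concentration tested (going by the name of the read-out) and lower numbers for less inhibition. Compound 1 `CCNC(=O)C1=C(C)NC(=O)NC1c1ccoc1` gives 1% in this assay, and compound 2 `CC1=C(C(=O)SC(C)C)C(c2ccco2)NC(=O)N1` gives 5% in this assay. Compound 2 holds the numerically higher of the two figures, but compound 1, its nearest neighbour, lies only a few points lower, a gap inside the usual scatter, so the two cannot be ranked against each other. Both numbers are small, meaning that at the one concentration tested very little of the labelled ligand is displaced.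

Compound 3 `CC1=C(C(=O)SC(C)C)C(c2ccoc2)NC(=O)N1` has not yet been measured. It is built from the same atoms as compound 2, joined differently: furan-3-yl in place of furan-2-yl on a saturated ring carbon. For the measured compounds named here, no pair of measured compounds differs in just this way, so there is no earlier step to lean on. Given that compound 2 gives only 5%, compound 3 is expected to stay in the same low region, with an expected step of a number 2 percentage points lower from compound 2 to compound 3 (within the scatter) that does not exceed the scatter. Compound 3 is therefore estimated at 3%, expected to fall between 0% and 15%.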

Compound 3, a percentage reported as inhibition, at one concentration (the size of the read-out at that concentration, not a potency): 9%
Compound 3: the middle estimate sits 6 percentage points below what was measured; the range from low to high includes it.
By their numbers in this assay, from the lowest: compounds 1, 2 and 3 (each within the scatter of the next).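

In this assay, swapping the point at which the furan is attached, with furan-3-yl in place of furan-2-yl on a saturated ring carbon, gives a number 4 percentage points higher from compound 2 to compound 3 (within the scatter), so at this position the two furan forms cannot be told apart by this test. For the compounds shown here, compound 3 also adds the first comparison at the carbonyl carbon in which only one place differs: isopropylsulfanyl in place of ethylamino gives a number 8 percentage points higher from compound 1 to compound 3 (within the scatter), so this larger change of atoms cannot be separated from ordinary repeat-to-repeat variation either. No supporting information is available to explain either result.

Going by these compounds alone, because every step so far stays within the scatter, it remains open whether a different kind of group, such as a phenyl ring in place of the furan or a carboxylic acid or longer amine chain on the carbonyl carbon, would give a clearly different number. A reading at one concentration is also not a potency, so any small differences among these compounds that might appear at other concentrations remain unknown.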